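The compounds below may be only part of what the source reports. "The series", "measured", "known", "first", "only" and "open" are said of these compounds alone.

Compound 1 `O=C(C1CC(F)C1)N1CCc2nc(C#Cc3ccccc3)sc2C1` gives 85 nM in an assay on HEK293 cells for positive allosteric modulation of metabotropic glutamate receptor 5 (Homo sapiens), read by FLIPR, with a stated time of 1 h; a higher number here means that more compound is needed for the effect, a lower number that less compound is needed.
Compound 2 `COC1CC(C(=O)N2CCc3nc(C#Cc4ccccc4)sc3C2)C1` gives 640 nM in this assay.
Compound 3 `O=C(C1CCCCC1)N1CCc2nc(C#Cc3ccccc3)sc2C1` gives 167 nM in this assay.

Compound 3 holds the second highest of these three numbers. Its nearest neighbour is compound 1, with a 2.0-fold higher number from compound 1 to compound 3 (0.29 log units; within the scatter), a gap within the scatter; its furthest is compound 2, with a 3.8-fold lower number from compound 2 to compound 3 (0.58 log units; beyond the scatter), a gap beyond the scatter. Compound 4 `Cc1cccc(C(=O)N2CCc3nc(C#Cc4ccccc4)sc3C2)n1` has not yet been measured. It differs from compound 3 in one place: 6-methylpyridin-2-yl in place of cyclohexyl on a carbonyl carbon. Among the measured compounds shown here, two measured steps touch the same carbonyl carbon, a 2.0-fold higher number from compound 1 to compound 3 (0.29 log units; within the scatter) and a 3.8-fold lower number from compound 2 to compound 3 (0.58 log units; beyond the scatter), and both swap one saturated ring for another. Neither of them puts a six-membered aromatic ring with a hetero atom at that place, so the data give no direct guide to the move toward compound 4. Since the measured exchanges at this carbon ranged from within the scatter to a modest shift, compound 4 is expected to land near compound 3, with a 1.1-fold lower number from compound 3 to compound 4 (0.05 log units; within the scatter) not beyond the scatter. Compound 4 is therefore estimated at 150 nM, in a range from 50 nM to 500 nM.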

Compound 4, half-maximal effective concentration: 160 nM
Estimate against measurement, compound 4: 1.1-fold (0.03 log units) below; measured number inside the range.
By their numbers in this assay, from the lowest: compounds 1, 4 and 3 (each within the scatter of the next); then compound 2.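

Among the compounds shown here, for the first time an aromatic ring stands on this carbonyl carbon, and in this assay the 6-methylpyridin-2-yl group of compound 4 cannot be told apart from cyclohexyl, with a 1.0-fold lower number from compound 3 to compound 4 (0.02 log units; within the scatter) as the step, or from 3-fluorocyclobutyl, with a 1.9-fold higher number from compound 1 to compound 4 (0.27 log units; within the scatter) as the step. The place therefore tolerates a six-membered aromatic ring with 1 hetero atom as well as the saturated rings of compound 1 and compound 3, while 3-methoxycyclobutyl stays apart, with a 4.0-fold lower number from compound 2 to compound 4 (0.60 log units; beyond the scatter) as the step beyond the scatter. Nothing available explains these results.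

From the compounds shown here alone, it remains open how a plain phenyl or an unsubstituted pyridin-2-yl group would compare at this carbonyl carbon, which would separate the share of the methyl from that of the ring nitrogen. Going by these compounds, how an amine or a carboxylic acid on that ring would fare also stays open.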